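The compounds below may be only part of what the source reports. "The series", "measured", "known", "first", "only" and "open" are said of these compounds alone.

Measured so far:

Compound 1 `CN(C)C(=O)c1cc2cnc(Nc3ccc(S(=O)(=O)NCCCN=C=S)cc3)nc2n1C1CCCC1`: in a functional assay on A549 cells (Homo sapiens) for inhibition, read by CCK-8 assay, with a stated time of 72 h, tested at 1 uM (on this read-out lower numbers stand for a weaker effect and higher numbers for a stronger effect at the one concentration tested), compound 1 gives 58.9%.
Compound 2 `CN(C)C(=O)c1cc2cnc(Nc3ccc(C(=O)NCCCN=C=S)cc3)nc2n1C1CCCC1`: in this assay compound 2 gives 32.9%.

Going by the values given here, compound 2 stands at the lower of the two numbers; the only measured step, a number 26 percentage points lower from compound 1 to compound 2 (beyond the scatter), separates it from compound 1, and that step swaps the group that joins the aromatic carbon to the chain, not the chain itself. Compound 3 `CN(C)C(=O)c1cc2cnc(Nc3ccc(C(=O)NCCCCCN=C=S)cc3)nc2n1C1CCCC1` keeps the whole framework of compound 2 and differs from it only at the far end of the chain: a group of 5 heavy atoms (3 carbon, 1 nitrogen, 1 sulfur; no ring) in place of a group of 3 heavy atoms (1 carbon, 1 nitrogen, 1 sulfur; no ring), on a saturated chain carbon, three bonds along the chain from an amide-type nitrogen. Among the compounds with values here, no measured step touches this part of the molecule, so nothing in the data says whether a longer chain between the amide-type nitrogen and the terminal group raises or lowers the number. Without a comparable step to lean on, the cautious expectation is that the number of compound 3 stays near that of compound 2, with any step of the kind of a number 0.1 percentage points higher from compound 2 to compound 3 (within the scatter) expected to fall within the usual scatter. Compound 3 is therefore expected to give about 33% in this assay, between 15% and 55%.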

Compound 3, a percentage reported as inhibition, at one concentration (the size of the read-out at that concentration, not a potency): 29.3%
For compound 3 the middle estimate is 3.7 percentage points above the measured one; low and high end bracket the measured number.
By their numbers in this assay, from the lowest: compounds 3 and 2 (each within the scatter of the next); then compound 1.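

In this assay, extending the chain gives a number 3.6 percentage points lower from compound 2 to compound 3 (within the scatter), so the group of 5 heavy atoms and the group of 3 heavy atoms, on a saturated chain carbon, three bonds along the chain from an amide-type nitrogen, cannot be told apart on this read-out. The extra chain length on the carbonyl-linked framework also leaves compound 3 well short of the sulfonyl-linked compound 1, as a number 29.6 percentage points lower from compound 1 to compound 3 (beyond the scatter) shows, so this one extension does not close the gap that separates the two frameworks. No separate measurement is available to explain these numbers.

On these data alone, it remains open whether a still longer chain on the carbonyl-linked framework would give a number beyond the scatter, and whether the same extension would give a similar result on the sulfonyl-linked framework of compound 1. Also open, as far as these compounds go, is what the isothiocyanate end contributes, which a chain ending in an amine or a carboxylic acid would test, and how these compounds rank in potency, since each number comes from a single concentration.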